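A few compounds are considered here, and "the series" means these few. Any claim that something is new, unique, unknown or untested is made for them only; others in the source may bear on it.

Two carbamates open the set. Compound 1 `C#CCN1CCCC(OC(=O)Nc2ccccc2)C1` gives in an assay on BTI-TN-5B1-4 cells for inhibition of Amine oxidase [flavin-containing] A (Homo sapiens), read by fluorescence and Amplex Red, using microsomes, with a stated time of 15 min (on this read-out lower numbers stand for stronger inhibition and higher numbers for weaker inhibition), only a limit of the assay, > 100000 nM. Compound 2 `C#CCN1CCC(COC(=O)Nc2ccc(C(C)C)cc2)CC1` likewise gives only a limit in this assay, > 100000 nM. Compound 2 therefore stands at the limit of > 100000 nM in this assay, at which 2 of the 2 values shown sit, with no number of its own to anchor a comparison. Compound 3 `CC(C)c1ccc(NC(=O)OCC2CCN(Cc3ccccc3)CC2)cc1` differs from compound 2 by phenyl in place of ethynyl on a saturated chain carbon bound to an amine nitrogen in a ring. For the measured compounds named here, no measured pair isolates this change, and the step is expected to bring nothing beyond the scatter, a number no higher from compound 2 to compound 3 (the limit leaves the size open). Compound 3 is therefore expected to return a limit again, with an estimate of 100000 nM, between 20000 nM and 500000 nM.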

Compound 3, half-maximal inhibitory concentration: > 100000 nM
Compound 3: a limit, no number; the forecaster's own chance of this, stated with the estimate: 75%; the middle value sits exactly at the limit.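

Compound 2 and compound 3 both give only a limit, and no step can be read between them. The compounds shown leave open what phenyl in place of ethynyl does, and none of them yet gives a number in this assay.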